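A few compounds are considered here, and "the series" means these few. Any claim that something is new, unique, unknown or untested is made for them only; others in the source may bear on it.

In an ADME assay on THP-1 cells (Homo sapiens) for cytotoxicity, read by flow cytometry and propidium iodide staining, with a stated time of 72 h (a higher number here means a weaker inhibitor, a lower number a stronger inhibitor), compound 1 (`CC(=O)Nc1ccc2oc(-c3ccc(C(F)(F)F)cc3)cc(=O)c2c1`) gives 10000 nM and compound 2 (`Nc1ccc2oc(-c3ccc(F)cc3)cc(=O)c2c1`) gives 10000 nM as its reading, so compound 2 stands level with compound 1, within the scatter. Compound 3 (`Nc1ccc2oc(-c3ccc(C(F)(F)F)cc3)cc(=O)c2c1`) differs from compound 2 by a single change, trifluoromethyl in place of fluoro on an aromatic carbon, para to a large group. No measured step sizes this change directly. However, compound 1 also carries trifluoromethyl and reads 10000 nM in the same test, and compound 2 with fluoro reads 10000 nM there. No shift beyond the scatter is therefore expected in this assay for this exchange. The expected step, no change at the digits printed from compound 2 to compound 3 (within the scatter) in size, has no favoured direction. Compound 3 is estimated at 10000 nM (5000 nM to 20000 nM) in this test.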

Compound 3, half-maximal inhibitory concentration: 1900 nM
Compound 3: middle estimate off by 5.3-fold (0.72 log units), on the high side, outside the stated range (below it).
By their numbers in this assay, from the lowest: compound 3; then compounds 1 and 2 (each within the scatter of the next).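

In this assay, trifluoromethyl in place of fluoro on an aromatic carbon, para to a large group, gives a 5.3-fold lower number from compound 2 to compound 3 (0.72 log units; beyond the scatter), so this position does respond to the exchange when the nitrogen on the aromatic ring carries no acetyl. Hydrogen in place of acetyl on that nitrogen, with trifluoromethyl kept, gives a 5.3-fold lower number from compound 1 to compound 3 (0.72 log units; beyond the scatter). Among these three compounds, therefore, trifluoromethyl goes with a lower number only where the acetyl is absent, as compound 1 carries trifluoromethyl and acetyl together without reaching that level.

Going by these compounds, whether a chloro, nitrile or methoxy group at this position would also lower the number remains open, as does the outcome of a methyl or a longer acyl chain on the nitrogen. Nothing shown here speaks to the cause of either step.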